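Enantiomer swap in a dichloro lactam series: clearance notes

The compounds below may be only part of what the source reports. "The series", "measured", "known", "first", "only" and "open" are said of these compounds alone.

Measured so far:
- compound 1 `Cc1cc(C)c(CN2CCc3c(Cl)cc([C@@H](CO)[C@@H]4CCCO4)c(Cl)c3C2=O)c(=O)[nH]1`: 70.3 uL/min
- compound 2 `COC(c1cc(Cl)c2c(c1Cl)C(=O)N(Cc1c(C)cc(C)[nH]c1=O)CC2)C1CCN(C(C)=O)CC1`: 50.3 uL/min; 92.6 uL/min (2 entries)

Among the measured compounds shown here, in an ADME assay on microsomes from liver (Homo sapiens) for metabolic stability, read by LC-MS, using NADPH, with stated times of 10 min and 45 min, tested at 1 uM (on this read-out lower numbers stand for slow clearance and higher numbers for fast clearance), compound 1 gives 70.3 uL/min; it is the only compound here with a single number, since the repeat entries of compound 2 the several entries of compound 2 in this assay, 50.3 uL/min; 92.6 uL/min (2 entries) give no one value to set it against. Compound 3 `Cc1cc(C)c(CN2CCc3c(Cl)cc([C@H](CO)[C@H]4CCCO4)c(Cl)c3C2=O)c(=O)[nH]1` is the mirror image of compound 1: the two compounds have the same atoms and bonds and differ only in configuration as drawn: 2 of 2 stereo elements differ (all stereocentres are inverted: mirror images); a stereocentre at a saturated chain carbon is drawn S in compound 1 and R in compound 3; a stereocentre at a saturated ring carbon is drawn S in compound 1 and R in compound 3. For the measured compounds named here, no measured step of this kind exists in the set, so no shift beyond the usual scatter is expected, and the step of a 1.0-fold lower number from compound 1 to compound 3 (0.00 log units; within the scatter) is estimated as flat. Compound 3 is therefore expected to read about 70 uL/min, within 35 uL/min to 140 uL/min, in this assay.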

Compound 3, intrinsic clearance in a liver preparation (reported as CLH), per the amount of preparation that the assay uses: 51.6 uL/min
Estimate against measurement, compound 3: 1.4-fold (0.13 log units) above; low and high end bracket the measured number.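

Inverting both stereocentres, the saturated chain carbon and the saturated ring carbon, gives the first measured step at this position: a 1.4-fold lower number from compound 1 to compound 3 (0.13 log units; within the scatter). In this assay, the mirror images therefore cannot be told apart, and both still sit in the same range as the repeat entries of a compound with a different side chain: the several entries of compound 2 in this assay, 50.3 uL/min; 92.6 uL/min (2 entries)

Still open, from the compounds shown here alone, is how the two forms with only one stereocentre inverted would read. Also open, going by these compounds, is whether an amine or a carboxylic acid on the side chain would move the number beyond the scatter.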